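Extending the methoxy of compound 3 to ethoxy

The source may hold more compounds than are shown below. What is called first, only, known or untested is meant among the compounds shown, and "the series" means these compounds.

Measured compounds:
compound 1, `Nc1nc(NCc2ccc(C(F)(F)F)cc2)nc(-c2ccccc2CO)n1`: 5.03
compound 2, `Cc1ccc(CNc2nc(N)nc(-c3ccccc3CO)n2)cc1`: 4.38
compound 3, `COc1ccc(CNc2nc(N)nc(-c3ccccc3CO)n2)cc1`: 3.34

In a functional assay on cells for positive allosteric modulation of G-protein coupled receptor 68 (Homo sapiens), read by a luciferase reporter and cAMP accumulation, with a stated time of 30 min, at pH 6.8 and pH 8.3, in the presence of a further agent that is not named here (a lower number here means a less potent compound, a higher number a more potent compound, by a factor of ten per unit of this negative logarithm), compound 3 stands lowest of the three measured compounds. Its nearest neighbour is compound 2, and the step of a number 1.04 log units lower from compound 2 to compound 3 (beyond the scatter) lies beyond the scatter; the step of a number 1.69 log units lower from compound 1 to compound 3 (beyond the scatter) is larger still. The three compounds differ only in the group on the aromatic carbon, and the step of a number 0.65 log units lower from compound 1 to compound 2 (beyond the scatter) shows that the move from trifluoromethyl to methyl already costs potency before methoxy lowers it further.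

Compound 4, `CCOc1ccc(CNc2nc(N)nc(-c3ccccc3CO)n2)cc1`, is not yet measured. It differs from compound 3 by methyl in place of hydrogen on a saturated chain carbon bound to an oxygen on an aromatic ring. Among the measured compounds shown here, no measured step touches this place: all three steps swap the whole group on the aromatic carbon, whereas here the oxygen stays and only the chain beyond it grows by one carbon. The measured steps therefore bear on the change only indirectly, by showing that this part of the molecule is sensitive in this assay. For the measured compounds named here, with no direct precedent, the step from compound 3 to compound 4 is expected to be small, a number 0.16 log units higher from compound 3 to compound 4 (within the scatter), and not clearly beyond the scatter in either direction. Compound 4 is thus estimated at 3.5 in this assay, with a range from 2.8 to 4.3.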

Compound 4, negative logarithm of the antagonist equilibrium constant: 4.77
Compound 4: the middle estimate sits 1.27 log units below what was measured, outside the stated range (above it).
By their numbers in this assay, from the lowest: compound 3; then compound 2; then compounds 4 and 1 (each within the scatter of the next).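

In this assay the oxygen stays in place and a single added methyl on the saturated chain carbon gives a number 1.43 log units higher from compound 3 to compound 4 (beyond the scatter) in this comparison, so the low number of compound 3 belongs to methoxy and does not extend to ethoxy, even though the group is still bound through the same oxygen. The earlier compounds shown here had suggested that the oxygen-linked group was the poorest of those on the aromatic carbon, yet ethoxy gives a number 0.39 log units higher from compound 2 to compound 4 (beyond the scatter) when it replaces methyl, while its replacement of trifluoromethyl gives a number 0.26 log units lower from compound 1 to compound 4 (within the scatter) and so leaves the two groups indistinguishable here. The data at hand offer nothing that accounts for so large a step from one added carbon.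

The compounds shown leave open whether a longer chain such as propoxy or butoxy would extend this rise or reverse it, and whether branched isopropoxy would match ethoxy. They also leave open how an amine or a nitrile on the aromatic carbon would compare with ethoxy and trifluoromethyl.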